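Shortening the Chain of Compound 3

The source may report more compounds than this note shows. Statements on the series, on what has been measured and on what is new or still open speak of the compounds shown alone.

Measured in a functional assay on HCT-116 cells (Homo sapiens) for antiproliferative activity, read by MTT assay, with a stated time of 48 h; a higher number here means a weaker inhibitor of growth, a lower number a stronger inhibitor of growth:
- compound 1 `CCCCCN(Cc1ccc(C(=O)NO)cc1)c1ncc(-c2ccc(C)cc2)s1`: 23300 nM
- compound 2 `Cc1ccc(OCCCN(Cc2ccc(C(=O)NO)cc2)c2ncc(-c3ccc(C)cc3)s2)cc1`: 12600 nM
- compound 3 `Cc1ccc(OCCCCN(Cc2ccc(C(=O)NO)cc2)c2ncc(-c3ccc(C)cc3)s2)cc1`: 580 nM

Compound 3 has the lowest number of the three, and its gaps to the other two lie beyond the scatter. Compound 4 `Cc1ccc(-c2cnc(N(CCCOc3ccccc3)Cc3ccc(C(=O)NO)cc3)s2)cc1` differs from it as follows: phenoxy in place of (4-methylphenoxy)methyl on a saturated chain carbon, three bonds along the chain from a nitrogen on an aromatic ring. Put another way, 4-(4-methylphenoxy)butyl gives way to 3-phenoxypropyl.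

The most relevant measurement is a 22-fold lower number from compound 2 to compound 3 (1.34 log units; beyond the scatter), a large step that placed (4-methylphenoxy)methyl on the same carbon where 4-methylphenoxy had stood. The new change runs almost in reverse. The large 40-fold lower number from compound 1 to compound 3 (1.60 log units; beyond the scatter) also shows that the group on this nitrogen can matter, whereas a 1.8-fold lower number from compound 1 to compound 2 (0.27 log units; within the scatter) stays within the scatter. For the measured compounds named here, no measured pair isolates the loss of the methyl on the phenoxy ring, so the range must stay wide.

A large rise is therefore expected in this assay, with an estimated 16-fold higher number from compound 3 to compound 4 (1.19 log units; beyond the scatter). The expected value for compound 4 is 9000 nM, within an estimated range of 3000 nM to 25000 nM.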

Compound 4, concentration for 50% growth inhibition: 4140 nM
The estimate for compound 4 lay 2.2-fold (0.34 log units) above the measured number, within the range that was stated.
By their numbers in this assay, from the lowest: compound 3; then compound 4; then compounds 2 and 1 (each within the scatter of the next).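

In this assay, the loss of the methyl from the phenoxy ring can now be read alone (a 3.0-fold lower number from compound 2 to compound 4 (0.48 log units; beyond the scatter)), so this methyl matters at the 3-carbon chain length, and the ring without it gives the lower number. The phenoxy group now also separates clearly from the alkyl chain of compound 1 (a 5.6-fold lower number from compound 1 to compound 4 (0.75 log units; beyond the scatter)), whereas the methylated ring of compound 2 did not (a 1.8-fold lower number from compound 1 to compound 2 (0.27 log units; within the scatter)). The full swap of 4-(4-methylphenoxy)butyl for 3-phenoxypropyl still costs activity (a 7.1-fold higher number from compound 3 to compound 4 (0.85 log units; beyond the scatter)), and compound 3 keeps the lowest number of the four.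

No evidence is available on why these numbers move. As far as these compounds go, how a 4-phenoxybutyl chain, or an amine in place of the phenoxy ring, would behave remains open.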